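Bromo to fluoro on compound 1: working notes

A few compounds are considered here, and "the series" means these few. Any claim that something is new, unique, unknown or untested is made for them only; others in the source may bear on it.

- compound 1 `CC(=O)N1N=C(c2ccc3ccccc3c2)OC1c1ccccc1Br` gives 5.49 ug/mL
- compound 2 `CC(=O)N1N=C(c2ccc3ccccc3c2)OC1c1ccccc1Cl` gives 2.36 ug/mL
- compound 3 `CC(=O)N1N=C(c2ccc3ccccc3c2)OC1c1ccc(Cl)cc1` gives 2.63 ug/mL

These values come from a functional assay on MCF7 cells (Homo sapiens) for antiproliferative activity, read by MTT assay, with a stated time of 48 h; a lower number here means a stronger inhibitor, a higher number a weaker inhibitor. Compound 1 has the highest of the three numbers, while the other two lie within the scatter of each other (a 1.1-fold higher number from compound 2 to compound 3 (0.05 log units; within the scatter)).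

The next change leads to compound 4 `CC(=O)N1N=C(c2ccc3ccccc3c2)OC1c1ccccc1F`: fluoro in place of bromo on an aromatic carbon. This puts fluoro in place of bromo on an aromatic carbon, ortho to a large group.

The closest measured step is a 2.3-fold lower number from compound 1 to compound 2 (0.37 log units; beyond the scatter), with chloro in place of bromo on an aromatic carbon. The step of a 2.1-fold lower number from compound 1 to compound 3 (0.32 log units; beyond the scatter), with 4-chlorophenyl in place of 2-bromophenyl, is also modest. For the measured compounds named here, no fluoro compound has been measured, so neither step fixes the size for fluoro.

A modest step to a lower number is therefore expected in this assay, though it may stay within the scatter. The expected change is a 1.8-fold lower number from compound 1 to compound 4 (0.26 log units; within the scatter). For compound 4 the estimated value is 3 ug/mL, with an expected range of 1.4 ug/mL to 6.5 ug/mL.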

Compound 4, half-maximal inhibitory concentration: 3.44 ug/mL
Compound 4: the middle estimate sits 1.1-fold (0.06 log units) below what was measured; measured number inside the range.
By their numbers in this assay, from the lowest: compounds 2, 3, 4 and 1 (each within the scatter of the next, the first and the last beyond it).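

In this assay, fluoro on an aromatic carbon ortho to a large group gives a 1.6-fold lower number from compound 1 to compound 4 (0.20 log units; within the scatter), so this replacement of bromo stays within the scatter, whereas the chloro replacement in compound 2 goes beyond it. Fluoro also cannot be separated from either chloro compound, with a 1.5-fold higher number from compound 2 to compound 4 (0.16 log units; within the scatter) and a 1.3-fold higher number from compound 3 to compound 4 (0.12 log units; within the scatter). For the compounds shown here, compound 4 thus lies within the scatter of all three other compounds, and the only steps beyond the scatter in this set remain those from compound 1 to the two chloro compounds.

As far as these compounds go, whether an amine, a methoxy group or a carboxylic acid in place of the halogen would read any differently stays open. No supporting data are available to explain the differences among these halogen compounds.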